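One Fluorine Fewer on a Short Chain

The source may hold more compounds than are shown below. What is called first, only, known or untested is meant among the compounds shown, and "the series" means these compounds.

Compound 1, `FC(F)(F)CCOc1ccc2[nH]ccc2c1`, gives 2.8 in a physicochemical assay for lipophilicity, read by NMR; on this read-out higher numbers stand for higher lipophilicity and lower numbers for lower lipophilicity.
Compound 2, `CCCC(F)(F)CO`, gives 1.25 in this assay.
Compound 3, `FC(F)CCOc1ccc2[nH]ccc2c1`, gives 2.6 in this assay.

Compound 1 and compound 3 share a core and differ in one place: hydrogen in place of fluoro on a saturated chain carbon bound to two fluorine atoms and a saturated chain carbon. That change made a number 0.20 log units lower from compound 1 to compound 3 (within the scatter). Compound 2 sits lowest of the three; how its core differs from that of compound 1 is not broken down here, and only the two values themselves are compared, with compound 2 well under both compound 3 and compound 1.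

Compound 4, `CCCC(F)CO`, has not yet been measured in this assay. It differs from compound 2 by hydrogen in place of fluoro on a saturated chain carbon bound to a fluorine atom and two saturated chain carbons. This is the same kind of change as that from compound 1 to compound 3, though not the same: in compound 1 the place is a saturated chain carbon bound to two fluorine atoms and a saturated chain carbon, whereas in compound 2 it is a saturated chain carbon bound to a fluorine atom and two saturated chain carbons.

Set beside the earlier step, the expected step is a number 0.25 log units lower from compound 2 to compound 4 (within the scatter), resting on the single measured instance of this kind of change, a number 0.20 log units lower from compound 1 to compound 3 (within the scatter), and on the low starting value of compound 2, 1.25. On that basis compound 4 is estimated at 1 in this assay, expected to fall between 0.6 and 1.4.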

Compound 4, partition coefficient: 0.87
Beside the measured number, compound 4's estimate is 0.13 log units above it; the measured number falls inside the stated range.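

In this assay, replacing fluoro with hydrogen on the saturated chain carbon bound to a fluorine atom and two saturated chain carbons gave a number 0.38 log units lower from compound 2 to compound 4 (beyond the scatter) on the core of compound 2, while the related replacement on the core of compound 1 gave a number 0.20 log units lower from compound 1 to compound 3 (within the scatter) in the earlier pair. Only the new step stands clear of the scatter, so a firm difference is seen on the core of compound 2 alone, and the earlier pair does not by itself establish a shift that could be carried over. These two pairs, with the replacement made at differently substituted carbons, show neither that the step transfers from one core to the other nor that its size holds across the series, and nothing at hand explains the size of either step.

On these data alone, it remains open whether the same replacement would give a comparable step on a longer chain, or on a core carrying an amine or a carboxylic acid. The compounds shown also leave open what would happen if the remaining fluoro of compound 4 were replaced by hydrogen as well.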